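Swapping Methoxyphenyl Isomers on the Fluorinated Core of Compound 3

This account rests on a few compounds, and the source may have more. Where it says the series, first, only, none or still open, it means among the compounds named here.

In a functional assay on NCI-H460 cells (Homo sapiens) for cytotoxicity, read by MTT assay, with a stated time of 72 h (a lower number here means a stronger inhibitor, a higher number a weaker inhibitor), three compounds have been measured:

Compound 1 `COc1ccc(-c2cc(C(=O)Nc3ccc(Oc4ccnc5cc(OCCCN6CCCCC6)c(OC)cc45)c(F)c3)c3ccccc3n2)cc1` gives 290 nM
Compound 2 `COc1cccc(-c2cc(C(=O)Nc3ccc(Oc4ccnc5cc(OCCCN6CCCCC6)c(OC)cc45)c(F)c3)c3ccccc3n2)c1` gives 210 nM
Compound 3 `COc1cccc(-c2cc(C(=O)Nc3ccc(Oc4ccnc5cc(OCCCN6CCCCC6)c(OC)cc45)c(F)c3)c3cc(F)ccc3n2)c1` gives 1000 nM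

Compound 3 stands highest of the three, and its distance from both other compounds lies beyond the scatter. Compound 2 and compound 1 differ only in where the methoxy group sits on the outer phenyl ring, and that step, a 1.4-fold lower number from compound 1 to compound 2 (0.14 log units; within the scatter), stayed within the scatter. The larger movement came with the fluoro on the core, a 4.8-fold higher number from compound 2 to compound 3 (0.68 log units; beyond the scatter).

Compound 4 `COc1ccc(-c2cc(C(=O)Nc3ccc(Oc4ccnc5cc(OCCCN6CCCCC6)c(OC)cc45)c(F)c3)c3cc(F)ccc3n2)cc1` keeps that fluorinated core and makes the change (4-methoxyphenyl in place of 3-methoxyphenyl on an aromatic carbon). This is the same methoxyphenyl swap already seen between the first two compounds, only run in the opposite direction, so the step from compound 2 to compound 1 is the one that bears on it; it was small and within the scatter. The fluoro step is not touched here. A step no larger than the scatter is therefore expected, if anything a slightly higher number, which is estimated as a 1.4-fold higher number from compound 3 to compound 4 (0.15 log units; within the scatter).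

Compound 4 is expected to give about 1400 nM in this assay, with a likely range from 600 nM to 3200 nM.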

Compound 4, half-maximal inhibitory concentration: 240 nM
Estimate against measurement, compound 4: 5.8-fold (0.77 log units) above; measured number below the stated range.
By their numbers in this assay, from the lowest: compounds 2, 4 and 1 (each within the scatter of the next); then compound 3.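

In this assay, the swap to 4-methoxyphenyl from 3-methoxyphenyl, on the aromatic carbon next to the ring nitrogen, is not a small change on the fluorinated core, where it gives a 4.2-fold lower number from compound 3 to compound 4 (0.62 log units; beyond the scatter), so its size depends on the core that carries it: the same change on two cores in this assay, a 1.4-fold lower number (0.14 log units; within the scatter) from compound 1 to compound 2 and a 4.2-fold higher number (0.62 log units; beyond the scatter) from compound 4 to compound 3, 5.8-fold (0.76 log units) apart, beyond the scatter of two such steps

The fluoro behaves the same way, since with 4-methoxyphenyl in place it gives only a 1.2-fold lower number from compound 1 to compound 4 (0.08 log units; within the scatter), unlike the clear rise it gives with 3-methoxyphenyl: the same change on two cores in this assay, a 4.8-fold higher number (0.68 log units; beyond the scatter) from compound 2 to compound 3 and a 1.2-fold lower number (0.08 log units; within the scatter) from compound 1 to compound 4, 5.8-fold (0.76 log units) apart, beyond the scatter of two such steps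

Neither change can therefore be read alone, as the two do not simply add up, and among these four compounds the higher number appears only where fluoro and 3-methoxyphenyl occur together, in compound 3.

Four compounds cannot explain why this one pairing stands apart, and a single measured pairing of this kind could also owe part of its size to the scatter of the assay. Going by these compounds, it also remains open whether the same dependence would appear with a hydroxyl or an amine in place of the methoxy on the outer phenyl ring, or with chloro in place of the fluoro on the core.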